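A few compounds are considered here, and "the series" means these few. Any claim that something is new, unique, unknown or untested is made for them only; others in the source may bear on it.

Of the compounds shown here, three that share one core have been tested in an ADME assay on Huh-7 cells (Homo sapiens) for cytotoxicity; a lower number here means that less compound is tolerated, a higher number that more compound is tolerated. Compound 1 `COc1ccc(C(=O)NC(=S)N2CCc3c(OCCCCCOc4ccc(Cl)cc4)cccc32)cc1` gives 34400 nM. Compound 2 `CCCC(=O)NC(=S)N1CCc2c(OCCCCCOc3ccc(Cl)cc3)cccc21` reaches only the assay limit of > 50000 nM. Compound 3 `O=C(NC(=S)N1CCc2c(OCCCCCOc3ccc(Cl)cc3)cccc21)c1cccs1` gives 10700 nM, the lowest number among the measured values; the step of a 3.2-fold lower number from compound 1 to compound 3 (0.51 log units; beyond the scatter) lies beyond the scatter, and so does an at least 4.6-fold lower number from compound 2 to compound 3 (0.66 log units; beyond the scatter). Compound 4 `O=C(NC(=S)N1CCc2c(OCCCCCOc3ccc(Cl)cc3)cccc21)c1cc2ccccc2s1` is not yet measured; the change is 1-benzothiophen-2-yl in place of thiophen-2-yl on a carbonyl carbon. The measured steps replace 4-methoxyphenyl or propyl with thiophen-2-yl on the carbonyl carbon, and both lowered the number; none of them exchanges one aromatic ring for a larger fused one. Only a small step is therefore expected in this assay, a 1.6-fold lower number from compound 3 to compound 4 (0.22 log units; within the scatter), perhaps toward a lower number. Compound 4 is estimated at 6500 nM, between 2500 nM and 20000 nM.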

Compound 4, half-maximal cytotoxic concentration: > 50000 nM
Compound 4 was reported as a limit; the forecaster's own chance of this, stated with the estimate: 5%; middle value at least 7.6-fold (0.88 log units) from the limit.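

In this assay, a larger aromatic group on the carbonyl carbon does not extend the fall seen with thiophen-2-yl: 1-benzothiophen-2-yl gives an at least 4.6-fold higher number from compound 3 to compound 4 (0.66 log units; beyond the scatter). Against the 4-methoxyphenyl group it gives an at least 1.4-fold higher number from compound 1 to compound 4 (0.16 log units; that floor lies within the scatter), so only a floor is known. Compound 3 now sits beyond the scatter below each of the other three compounds, so the low number belongs to thiophen-2-yl alone among these groups, not to aromatic rings in general.

Going by these compounds, the step between compound 2 and compound 4 cannot be read, since both are limits: the limit of > 50000 nM in this assay, at which 2 of the 4 values shown sit. Whether furan-2-yl or pyridin-2-yl on the carbonyl carbon would also give a low number remains open.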